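Swapping 4-methylphenyl for 3,4-dimethoxyphenyl: an expected shift

This account rests on a few compounds, and the source may have more. Where it says the series, first, only, none or still open, it means among the compounds named here.

Measured in a physicochemical assay for lipophilicity, measured as octanol-water partition; on this read-out higher numbers stand for higher lipophilicity and lower numbers for lower lipophilicity:
Compound 1 `O=C(NNc1ccnc2cc(Cl)ccc12)c1ccccc1/N=C/c1ccc(Cl)c(Cl)c1`: 6.22
Compound 2 `O=C(NNc1ccnc2cc(Cl)ccc12)c1ccccc1/N=C/c1ccc(Br)cc1`: 5.76
Compound 3 `Cc1ccc(/C=N/c2ccccc2C(=O)NNc2ccnc3cc(Cl)ccc23)cc1`: 5.31

Compound 3, at 5.31, is the lowest of the three, and its gap to each of the others lies beyond the usual scatter. The unmeasured compound 4 `COc1ccc(/C=N/c2ccccc2C(=O)NNc2ccnc3cc(Cl)ccc23)cc1OC` keeps the shared core and differs from compound 3 in one group: 3,4-dimethoxyphenyl in place of 4-methylphenyl on a carbon with a double bond to nitrogen. Three measured steps change this same place: a number 0.46 log units lower from compound 1 to compound 2 (beyond the scatter) and a number 0.45 log units lower from compound 2 to compound 3 (beyond the scatter) and also a number 0.91 log units lower from compound 1 to compound 3 (beyond the scatter) (all modest). None of the groups in those steps contains oxygen, so they indicate how far this place can move the number but not the direction for the new group. A modest fall in this assay is therefore a tentative expectation, similar in size to the step of a number 0.45 log units lower from compound 2 to compound 3 (beyond the scatter) (the closest guide available). The expected change is a number 0.41 log units lower from compound 3 to compound 4 (beyond the scatter) (an estimate). For compound 4 the estimated value is 4.9, with an expected range from 4.4 to 5.4 (not yet measured).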

Compound 4, partition coefficient: 4.97
For compound 4 the middle estimate is 0.07 log units below the measured one; low and high end bracket the measured number.
By their numbers in this assay, from the lowest: compound 4; then compound 3; then compound 2; then compound 1.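

In this assay, within the data shown here, this is the first group at this place to carry oxygen and hydrogen-bond acceptors, and the number still falls, with a number 0.34 log units lower from compound 3 to compound 4 (beyond the scatter) even though 3,4-dimethoxyphenyl has more heavy atoms than 4-methylphenyl. Against the groups bearing halogens the distance is wider, with a number 0.79 log units lower from compound 2 to compound 4 (beyond the scatter) and a number 1.25 log units lower from compound 1 to compound 4 (beyond the scatter) as the widest step seen at this place. Among these compounds, compound 4 therefore lies below all three other compounds, and this position can move the number further than the earlier compounds showed.

Nothing measured here explains why the number falls with this change. From the compounds shown here alone, it also remains open whether a single methoxy group would give part of this fall, and where an amine or a carboxylic acid on the same ring would land.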